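Ester Variation and Metabolic Stability on a Shared Core

The source may hold more compounds than are shown below. What is called first, only, known or untested is meant among the compounds shown, and "the series" means these compounds.

Compound 1 `CCCCc1nc(C(C)C)c(CC(=O)OC)c(=O)n1Cc1ccc(-c2ccccc2-c2noc(=O)[nH]2)cc1` stands at the lower of the two numbers available in an ADME assay on microsomes from liver (Homo sapiens) for metabolic stability, with a stated time of 30 min (on this read-out lower numbers stand for a less stable compound and higher numbers for a more stable compound), where compound 1 gives 10.5%. Its nearest neighbour is compound 3 `CCCCc1nc(C(C)C)c(CC(=O)OC2CCCCC2)c(=O)n1Cc1ccc(-c2ccccc2-c2noc(=O)[nH]2)cc1`, which in this assay gives 13.3%; the step of a number 2.8 percentage points higher from compound 1 to compound 3 (within the scatter) allows no ordering of the two. In this assay compound 2 `CCCCc1nc(C(C)C)c(CC(=O)OCC(F)(F)F)c(=O)n1Cc1ccc(-c2ccccc2-c2noc(=O)[nH]2)cc1` gives "not determined" (no result reported), so no result was reported for it.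

Compound 4 `CC#CCOC(=O)Cc1c(C(C)C)nc(CCCC)n(Cc2ccc(-c3ccccc3-c3noc(=O)[nH]3)cc2)c1=O` differs from compound 1 by prop-1-yn-1-yl in place of hydrogen on a saturated chain carbon bound to an oxygen next to a carbonyl group. Among the measured compounds shown here, the one measured step that bears on this change, also made on an oxygen next to a carbonyl group, is a number 2.8 percentage points higher from compound 1 to compound 3 (within the scatter). Because the exchange from compound 1 to compound 3 produced only a number 2.8 percentage points higher from compound 1 to compound 3 (within the scatter), compound 1 and compound 3 give no reason to expect a larger move for a but-2-yn-1-yl ester on the same core. The expected step from compound 1 to compound 4 is therefore a number 1.5 percentage points higher from compound 1 to compound 4 (within the scatter), no change beyond the scatter. Compound 4 is accordingly estimated at 12% in this assay, between 4% and 24%.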

Compound 4, percent of the compound remaining: 13.7%
For compound 4 the middle estimate is 1.7 percentage points below the measured one; low and high end bracket the measured number.
By their numbers in this assay, from the lowest: compounds 1, 3 and 4 (each within the scatter of the next).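

At this position, on an oxygen next to a carbonyl group, the cyclohexyl exchange now has a second, open-chain counterpart, and its result is a number 3.2 percentage points higher from compound 1 to compound 4 (within the scatter), while the comparison between the two larger groups gives a number 0.4 percentage points higher from compound 3 to compound 4 (within the scatter). In this assay, methyl, cyclohexyl and but-2-yn-1-yl therefore cannot be ordered, and neither a ring nor a chain with a triple bond has moved the number beyond the scatter. The data shown offer no explanation for this result.

The compounds shown leave open whether a carboxylic acid or an amide in place of the ester would shift the number in this assay beyond the scatter. They also leave open whether a longer chain or a benzyl group on the same oxygen would do so.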